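The compounds below may be only part of what the source reports. "The series", "measured", "known", "first", "only" and "open" are said of these compounds alone.

Series notes, the step from compound 3 to compound 4.

Three compounds have numbers in a functional assay (aorta) with Oryctolagus cuniculus as the target; on this read-out higher numbers stand for weaker inhibition and lower numbers for stronger inhibition. Compound 1 `OCc1ccc(-c2nn(Cc3ccccn3)c3ccccc23)o1` gives 16000 nM, compound 2 `OCc1ccc(-c2nn(Cc3cncnc3)c3ccccc23)o1` gives 3200 nM and compound 3 `CCc1cnc(-c2nn(Cc3ccccc3F)c3ncccc23)nc1N` gives 272000 nM. Compound 3 stands highest of the three, above compound 1 and further still above compound 2. Among the measured compounds shown here, the single one-place step so far, a 5.0-fold lower number from compound 1 to compound 2 (0.70 log units; beyond the scatter), concerns the group on a saturated chain carbon bound to an aromatic nitrogen and so sits at a different place from the change now in view.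

Compound 4 `Nc1nc(-c2nn(Cc3ccccc3F)c3ncccc23)ncc1C1=CCCC1` differs from compound 3 by cyclopent-1-en-1-yl in place of ethyl on an aromatic carbon. For the measured compounds named here, no measured step touches this position, so the expectation rests only on the weak number of compound 3 and on the size of the group entering. Since the change is a carbon-only exchange without donors or acceptors, no step beyond the scatter in this assay is expected, with a slight lean toward a lower number. Compound 4 is therefore estimated at 200000 nM, within 60000 nM to 600000 nM. That estimate means a step of a 1.4-fold lower number from compound 3 to compound 4 (0.13 log units; within the scatter) from compound 3, which is expected to stay within the scatter.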

Compound 4, half-maximal inhibitory concentration: 836000 nM
For compound 4 the middle estimate is 4.2-fold (0.62 log units) below the measured one, and the stated range ends below it.
By their numbers in this assay, from the lowest: compound 2; then compound 1; then compound 3; then compound 4.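

In this assay the aromatic carbon ortho to an amino group proves sensitive to the group it carries: cyclopent-1-en-1-yl in place of ethyl gives a 3.1-fold higher number from compound 3 to compound 4 (0.49 log units; beyond the scatter), a step beyond the scatter. This position therefore registers a carbon-only exchange in which neither group carries hydrogen-bond donors or acceptors, and in this single pair the larger group, with 5 heavy atoms against 2, stands with the weaker inhibition. No measurement at hand accounts for this step.

One pair cannot separate the size of the group, its ring and its double bond, so a saturated cyclopentyl, a propyl chain or a methyl on this carbon would be the telling comparisons. On these data alone, whether an amine or a carboxylic acid here would move the number the other way also stays open.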